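This account rests on a few compounds, and the source may have more. Where it says the series, first, only, none or still open, it means among the compounds named here.

Compound 1 `CC(C)(C)c1ccc(C(=O)N2CCC3(CC2)C(=O)N(CC(=O)NCCC(=O)O)CN3c2ccccc2)cc1` was tested in an assay on HEK293 cells for displacement of a labelled ligand from NPC1-like intracellular cholesterol transporter 1 (Homo sapiens); on this read-out higher numbers stand for weaker inhibition and lower numbers for stronger inhibition. In this assay compound 1 gives 11400 nM, the highest of the two numbers recorded so far. For the measured compounds named here, the only other measured compound, compound 2 `COC(=O)CCCNC(=O)CN1CN(c2ccccc2)C2(CCN(C(=O)c3ccc(C4CCCCC4)cc3)CC2)C1=O`, gives 2500 nM in this assay. These two structures differ in more than one place, so their values can be set side by side, but the gap between them cannot be traced to any single structural change.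

Compound 3 `CC(C)(C)c1ccc(C(=O)N2CCC3(CC2)C(=O)N(CC(=O)NCN)CN3c2ccccc2)cc1` has not yet been measured. It differs from compound 1 in one place: amino in place of carboxymethyl on a saturated chain carbon bound to an amide-type nitrogen. Going by the values given here, no pair of measured compounds differs in exactly one place, so nothing in the recorded numbers shows how a change of this kind moves the read-out of this assay. With compound 1 as the only anchor, compound 3 is expected to land near it, at roughly 15000 nM in this assay, within a range from 4000 nM to 60000 nM. The expected step is a 1.3-fold higher number from compound 1 to compound 3 (0.12 log units; within the scatter), a shift that is estimated to stay within the usual scatter, with no clear direction either way.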

Compound 3, half-maximal inhibitory concentration: 26500 nM
Beside the measured number, compound 3's estimate is 1.8-fold (0.25 log units) below it; measured number inside the range.
By their numbers in this assay, from the lowest: compound 2; then compound 1; then compound 3.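

In this assay, putting amino in place of carboxymethyl on a saturated chain carbon bound to an amide-type nitrogen gives a 2.3-fold higher number from compound 1 to compound 3 (0.37 log units; beyond the scatter), so weaker inhibition follows this change. For the compounds shown here, this is the first step here that can be traced to a single place in the structure, and it shows that the end of this chain is not a silent spot: with the rest of compound 1 held fixed, the read-out moves by a modest but real amount when 4 heavy atoms are replaced by 1. Nothing measured here accounts for the shift, so it stands as an observation without an explanation.

The same difference can also be read as 2-carboxyethyl to aminomethyl. The end group and the chain length change together, and this single pair cannot tell the two apart. A 2-aminoethyl group at the same place would keep the chain length of compound 1 with the amine at its end, while a hydroxymethyl group would show whether a short chain behaves the same way without any nitrogen at its end.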